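The source may report more compounds than this note shows. Statements on the series, on what has been measured and on what is new or still open speak of the compounds shown alone.

Compound 1 `Cc1ccc2ncc(S(=O)(=O)c3ccc(F)cc3)c(N3CCC(C)CC3)c2c1`, compound 2 `Cc1ccc2ncc(S(=O)(=O)c3cc(Cl)cc(Cl)c3)c(N3CCC(C)CC3)c2c1` and compound 3 `CC1CCN(c2c(S(=O)(=O)c3cc(Cl)cc(Cl)c3)cnc3cc(F)ccc23)CC1` have all been measured in an assay on isolated protein for displacement of a labelled ligand from metabotropic glutamate receptor 5 (Homo sapiens), with a stated time of 60 min, tested at 1 uM; on this read-out higher numbers stand for more inhibition at the one concentration tested (going by the name of the read-out) and lower numbers for less inhibition. In this assay compound 1 gives 90%, compound 2 gives 75% and compound 3 gives 87%. Compound 2 and compound 1 differ in a single place, (4-fluorophenyl in place of 3,5-dichlorophenyl on a sulfonyl sulfur), and that change made a number 15 percentage points higher from compound 2 to compound 1 (beyond the scatter). The difference between the core of compound 2 and the core of compound 3 is not broken down here. Compound 4 `CC1CCN(c2c(S(=O)(=O)c3ccc(F)cc3)cnc3cc(F)ccc23)CC1` has not yet been measured; it differs from compound 3 by the same change, (4-fluorophenyl in place of 3,5-dichlorophenyl on a sulfonyl sulfur). Because compound 3 already gives 87% and the read-out has little room left to climb, a smaller step is expected, about a number 5 percentage points higher from compound 3 to compound 4 (within the scatter). Compound 4 is therefore estimated at 92%, most likely between 82% and 99%.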

Compound 4, a percentage reported as inhibition, at one concentration (the size of the read-out at that concentration, not a potency): 74.5%
Compound 4: the middle estimate sits 17.5 percentage points above what was measured; the measured number lies below the stated range.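

In this assay, putting 4-fluorophenyl in place of 3,5-dichlorophenyl on the sulfonyl sulfur gave a number 12.5 percentage points lower from compound 3 to compound 4 (beyond the scatter). Set beside the earlier step, this shows that the change does not carry over from one core to the other in this series, not even in direction: the same change on two cores in this assay, a number 15 percentage points higher (beyond the scatter) from compound 2 to compound 1 and a number 12.5 percentage points lower (beyond the scatter) from compound 3 to compound 4, 27.5 percentage points apart, beyond the scatter of two such steps The result rests on only two pairs of compounds, each tested at one concentration, and it does not show which part of the core matters or how the core alters the effect of the change.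

As far as these compounds go, it remains open whether other groups on the sulfonyl sulfur, such as a plain phenyl or a methoxyphenyl, would also behave differently on the two cores.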